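This account rests on a few compounds, and the source may have more. Where it says the series, first, only, none or still open, it means among the compounds named here.

Three compounds share one core and differ only in the group on the outer aromatic ring. In an assay on isolated protein for inhibition of Amine oxidase [flavin-containing] A (Homo sapiens), read by fluorescence, with stated times of 15 min and 20 min (on this read-out lower numbers stand for stronger inhibition and higher numbers for weaker inhibition), compound 1 `COc1ccc(C2=NN(C(=O)CN3CCCCC3)C(c3ccccc3O)C2)cc1` gives 12700 nM. Compound 2 `Cc1ccc(C2=NN(C(=O)CN3CCCCC3)C(c3ccccc3O)C2)cc1` gives 11300 nM in this assay. Compound 3 `O=C(CN1CCCCC1)N1N=C(c2ccc(F)cc2)CC1c1ccccc1O` gives 8020 nM in this assay, the lowest number of the three, though every gap stays within the scatter: a 1.6-fold lower number from compound 1 to compound 3 (0.20 log units; within the scatter) and a 1.4-fold lower number from compound 2 to compound 3 (0.15 log units; within the scatter). Compound 4 `O=C(CN1CCCCC1)N1N=C(c2ccc(Cl)cc2)CC1c1ccccc1O` follows from compound 3 by chloro in place of fluoro on an aromatic carbon. The measured steps that bear on this site are a 1.1-fold lower number from compound 1 to compound 2 (0.05 log units; within the scatter), a 1.6-fold lower number from compound 1 to compound 3 (0.20 log units; within the scatter) and a 1.4-fold lower number from compound 2 to compound 3 (0.15 log units; within the scatter), none beyond the scatter. No shift beyond the scatter is therefore expected for compound 4, and the estimated step is a 1.1-fold lower number from compound 3 to compound 4 (0.06 log units; within the scatter). Compound 4 is expected to give about 7000 nM in this assay, within a range of 3000 nM to 16000 nM.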

Compound 4, half-maximal inhibitory concentration: 7250 nM
Compound 4: middle estimate off by 1.0-fold (0.02 log units), on the low side; the measured number falls inside the stated range.
By their numbers in this assay, from the lowest: compounds 4, 3, 2 and 1 (each within the scatter of the next).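

In this assay the change from 4-fluorophenyl to 4-chlorophenyl gives a 1.1-fold lower number from compound 3 to compound 4 (0.04 log units; within the scatter) and chloro in place of methyl gives a 1.6-fold lower number from compound 2 to compound 4 (0.19 log units; within the scatter) while chloro in place of methoxy gives a 1.8-fold lower number from compound 1 to compound 4 (0.24 log units; within the scatter) so a fourth group on this aromatic carbon, para to a large group, still brings no step beyond the scatter. These four groups are therefore not told apart by this read-out. No available evidence bears on why.

Open, going by these compounds, is whether an amine, a carboxylic acid or a nitrile at this position would shift the number beyond the scatter. Also open, on these data alone, is whether a change elsewhere on the shared core would do so.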